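Swapping 4-fluorobenzyl for Cyclohexylmethyl: Expected Cytotoxicity

This account rests on a few compounds, and the source may have more. Where it says the series, first, only, none or still open, it means among the compounds named here.

Compound 2 `CS(=O)(=O)Nc1ccc2c(c1)S(=O)(=O)C=C(c1c(O)c3cc(F)ccc3n(Cc3ccc(F)cc3)c1=O)N2` gives in an ADME assay on 2209-23 cells (Homo sapiens) for cytotoxicity, read by WST assay (a lower number here means that less compound is tolerated, a higher number that more compound is tolerated), only a limit, > 50000 nM. Compound 1 `O=c1c(C2=CS(=O)(=O)c3cc(F)ccc3N2)c(O)c2cc(F)ccc2n1Cc1ccc(F)cc1` likewise sits at a limit of > 50000 nM. Compound 3 `COc1ccc2c(c1)c(O)c(C1=CS(=O)(=O)c3cc(NS(C)(=O)=O)ccc3N1)c(=O)n2Cc1ccc(F)cc1` also reaches only a limit, > 50000 nM. The two measured steps have no readable size, a step that the two limits leave unreadable from compound 1 to compound 2 and a step that the two limits leave unreadable from compound 2 to compound 3, because of the limit of > 50000 nM in this assay, at which 3 of the 3 values shown sit. Compound 4 `CS(=O)(=O)Nc1ccc2c(c1)S(=O)(=O)C=C(c1c(O)c3cc(F)ccc3n(CC3CCCCC3)c1=O)N2` differs from compound 2 by cyclohexyl in place of 4-fluorophenyl on a saturated chain carbon bound to an aromatic nitrogen. Neither measured step touches this part of the molecule, so no direction can be drawn from them; the only hint is that every measured compound tolerates the highest amount tested. Compound 4 is therefore expected to sit at a limit again, with an estimated 60000 nM between 25000 nM and 150000 nM. The expected step is a step that the limit leaves unreadable from compound 2 to compound 4.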

Compound 4, half-maximal cytotoxic concentration: > 50000 nM
Compound 4: a limit, no number; the forecaster's own chance of this, stated with the estimate: 85%; the middle value lies beyond the limit too.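

Compound 2 and compound 4 both give only a limit, so no size can be read for the change from 4-fluorobenzyl to cyclohexylmethyl: the limit of > 50000 nM in this assay, at which 4 of the 4 values shown sit.

The compounds shown leave open where the true cytotoxic concentrations lie in this assay, and whether any of these changes shifts them.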